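Second chloro on the core of compound 2

The compounds below may be only part of what the source reports. "The series", "measured", "known", "first", "only" and "open" are said of these compounds alone.

Three compounds have numbers in a functional assay on BT-549 cells (Homo sapiens) for cytotoxicity, read by sulforhodamine B assay, with a stated time of 48 h; on this read-out lower numbers stand for stronger inhibition of growth and higher numbers for weaker inhibition of growth. Compound 2 `ClCc1ccc(Cn2cnc3ncnc(Cl)c32)cc1` gives 3710 nM, the lowest of the three. Compound 1 `Nc1nc(Cl)c2ncn(Cc3ccccc3CCl)c2n1` gives 8130 nM, and compound 3 `ClCc1cccc(Cn2cnc3ncnc(Cl)c32)c1` gives 13200 nM; both gaps to compound 2 lie beyond the scatter. Compound 4 `ClCc1ccc(Cn2cnc3nc(Cl)nc(Cl)c32)cc1` has not yet been measured. It differs from compound 2 in one place: chloro in place of hydrogen on an aromatic carbon. Within the data shown here, no measured pair in this set carries the same change, so its effect cannot be read off from the numbers. The expected step of a 1.2-fold lower number from compound 2 to compound 4 (0.09 log units; within the scatter) is none beyond the scatter. The data offer no ground for a larger shift in either direction. For compound 4 the estimate is 3000 nM, with a range from 1200 nM to 8000 nM.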

Compound 4, concentration for 50% growth inhibition: 1860 nM
Compound 4: the middle estimate sits 1.6-fold (0.21 log units) above what was measured; measured number inside the range.
By their numbers in this assay, from the lowest: compounds 4 and 2 (each within the scatter of the next); then compounds 1 and 3 (each within the scatter of the next).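

In this assay, chloro in place of hydrogen on the aromatic carbon between two ring nitrogen atoms gives a 2.0-fold lower number from compound 2 to compound 4 (0.30 log units; within the scatter), so this position accepts the chloro group without a step beyond the scatter. Among these compounds, this single pair is the only reading of any change at this position, and it cannot show a trend. Nothing on hand bears on what lies behind the step.

Open, on these data alone, is whether a methyl, a methoxy or a bromo group at this position would stay within the scatter of compound 2. Also open, as far as these compounds go, is whether the chloro group would give a similar step on compound 3.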